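Ethyl in place of phenyl on the carbonyl of compound 1

A few compounds are considered here, and "the series" means these few. Any claim that something is new, unique, unknown or untested is made for them only; others in the source may bear on it.

Compound 1 `CC1(C)SC(c2ccccc2N)=NN1C(=O)c1ccccc1` is tested in an assay on isolated protein for inhibition of Nitric oxide synthase, inducible (Homo sapiens), read by scintillation counting, with a stated time of 30 min, tested at 50 uM (a higher number here means more inhibition at the concentration tested (going by the name of the read-out), a lower number less inhibition), where compound 1 gives 39.8%. Two relatives differ from it only on the aromatic ring: compound 2 `COc1ccc(N)c(C2=NN(C(=O)c3ccccc3)C(C)(C)S2)c1` gives 0% and compound 3 `CC1(C)SC(c2cc(Cl)ccc2N)=NN1C(=O)c1ccccc1` gives 20.8%, so compound 1 stands highest of the three, with a number 39.8 percentage points lower from compound 1 to compound 2 (beyond the scatter), a number 19 percentage points lower from compound 1 to compound 3 (beyond the scatter) and a number 20.8 percentage points higher from compound 2 to compound 3 (beyond the scatter). Compound 4 `CCC(=O)N1N=C(c2ccccc2N)SC1(C)C` alters a different part of compound 1: ethyl in place of phenyl on a carbonyl carbon. Among the compounds with values here, no measured step touches the group on the carbonyl carbon, so the three ring steps bear on it only loosely, showing that each change tried so far lowered the number. The expectation is uncertain and leans lower: compound 4 is estimated at 28%, between 5% and 50%. That would be an expected a number 11.8 percentage points lower from compound 1 to compound 4 (beyond the scatter).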

Compound 4, a percentage reported as inhibition, at one concentration (the size of the read-out at that concentration, not a potency): 19.2%
Compound 4: the middle estimate sits 8.8 percentage points above what was measured; low and high end bracket the measured number.
By their numbers in this assay, from the lowest: compound 2; then compounds 4 and 3 (each within the scatter of the next); then compound 1.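

Within the data shown here, replacing the phenyl on the carbonyl carbon with ethyl gives a number 20.6 percentage points lower from compound 1 to compound 4 (beyond the scatter) in this assay, the first evidence that the group on the carbonyl matters and not only the substituents on the aromatic ring. The phenyl can go without abolishing inhibition, so this position accepts a small group lacking any ring, though at a cost. No measurement here explains the drop. Still open, from the compounds shown here alone, is how a longer chain such as butyl, a methyl, or an amine on the carbonyl carbon would behave.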